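The compounds below may be only part of what the source reports. "The series", "measured", "known", "first", "only" and "open" are said of these compounds alone.

Of the compounds shown here, three sharing one core have been measured in an assay on HeLa cells for inhibition of sphingosine-1-phosphate transporter SPNS2 (Mus musculus), read by LC-MS, tested at 2 uM; on this read-out lower numbers stand for less inhibition and higher numbers for more inhibition at the one concentration tested (going by the name of the read-out). Compound 1 `CCCCCCCCCCc1ccc(-c2noc(CCCNC)n2)cc1` gives 45%. Compound 2 `CCCCCCCCCCc1ccc(-c2noc(C3CCNC3)n2)cc1` gives 26%, and compound 3 `CCCCCCCCCCc1ccc(-c2noc([C@@H]3CC[C@H](N)C3)n2)cc1` gives 38%. Compound 3 thus stands second highest of the three: its distance from compound 1 lies within the scatter, while the step of a number 12 percentage points higher from compound 2 to compound 3 (beyond the scatter) is modest but beyond it. Compound 4 `CCCCCCCCCCc1ccc(-c2noc(CC(CN)OC(C)=O)n2)cc1` has not yet been measured. It differs from compound 3 in one place: a group of 8 heavy atoms (5 carbon, 1 nitrogen, 2 oxygen; no ring) in place of a group of 6 heavy atoms (5 carbon, 1 nitrogen; one five-membered non-aromatic ring of carbon only), on an aromatic carbon. The measured steps that bear on this change are a number 7 percentage points lower from compound 1 to compound 3 (within the scatter), where a chain without a ring gave way to a ring with no change beyond the scatter, and a number 19 percentage points lower from compound 1 to compound 2 (beyond the scatter), where a different ring lowered the number. Compound 4 returns to a group without a ring, so the step back out of the ring is expected to be small, a number 2 percentage points lower from compound 3 to compound 4 (within the scatter). Compound 4 is therefore estimated to give 36%, between 16% and 56%.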

Compound 4, a percentage reported as inhibition, at one concentration (the size of the read-out at that concentration, not a potency): 0%
Beside the measured number, compound 4's estimate is 36 percentage points above it; the whole stated range lies above it.
By their numbers in this assay, from the lowest: compound 4; then compound 2; then compounds 3 and 1 (each within the scatter of the next).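

Among the compounds shown here, at this place on the five-membered aromatic ring, the chain carrying an acetyloxy group gives a number 38 percentage points lower from compound 3 to compound 4 (beyond the scatter) and a number 26 percentage points lower from compound 2 to compound 4 (beyond the scatter) and also a number 45 percentage points lower from compound 1 to compound 4 (beyond the scatter), and compound 4 sits at 0%, the only number here that reaches the bottom of the scale. Compounds 1 and 3 lie within the scatter of each other and left it possible that having no ring mattered little, but compound 4 shows that a group without a ring can still lose all of the inhibition seen at the one concentration tested. Nothing measured here explains this loss. The compounds shown leave open whether the loss belongs to the acetyloxy group itself or to the way the chain is branched. A hydroxyl or methoxy group on the same chain, or the same chain with no branch, could separate those two readings.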